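Propyl in Place of Methoxy: Expected Tolerance of Compound 3

A few compounds are considered here, and "the series" means these few. Any claim that something is new, unique, unknown or untested is made for them only; others in the source may bear on it.

compound 1, `COc1ccc(Nc2nccs2)cc1OCC=C(C)C`: 42000 nM
compound 2, `CC(C)=CCOc1cc(Nc2nccs2)ccc1Cl`: 26000 nM

Of the compounds shown here, two have been measured in a functional assay on MT2 cells (Homo sapiens) for cytotoxicity, read by MTT assay; a higher number here means that more compound is tolerated, a lower number that less compound is tolerated. Compound 1 `COc1ccc(Nc2nccs2)cc1OCC=C(C)C` gives 42000 nM, the higher of the two numbers, and compound 2 `CC(C)=CCOc1cc(Nc2nccs2)ccc1Cl` gives 26000 nM; the step of a 1.6-fold lower number from compound 1 to compound 2 (0.21 log units; within the scatter) leaves the pair within the scatter. Compound 3 `CCCc1ccc(Nc2nccs2)cc1OCC=C(C)C` has not yet been measured. It differs from compound 1 by propyl in place of methoxy on an aromatic carbon. Among the measured compounds shown here, one measured step bears on this change, since it also replaces that methoxy group, though with chloro rather than propyl, and it was a 1.6-fold lower number from compound 1 to compound 2 (0.21 log units; within the scatter). Nothing measured here separates one replacement of the methoxy from another. A small step in this assay, in either direction and not beyond the scatter, is therefore expected: a 1.2-fold lower number from compound 1 to compound 3 (0.08 log units; within the scatter). For compound 3 the estimate is 35000 nM, with a range from 15000 nM to 80000 nM.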

Compound 3, half-maximal cytotoxic concentration: 23000 nM
Estimate against measurement, compound 3: 1.5-fold (0.18 log units) above; the range from low to high includes it.
By their numbers in this assay, from the lowest: compounds 3, 2 and 1 (each within the scatter of the next).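

In this assay, propyl at this position, ortho to the (3-methylbut-2-en-1-yl)oxy group and para to the (1,3-thiazol-2-yl)amino group, gives a 1.8-fold lower number from compound 1 to compound 3 (0.26 log units; within the scatter), so a purely carbon chain with no hydrogen-bond acceptor stays within the scatter of methoxy, as chloro did. Propyl and chloro cannot be told apart either, at a 1.1-fold lower number from compound 2 to compound 3 (0.05 log units; within the scatter), so all three groups at this position now lie within the scatter of one another. Nothing available explains how close these readings lie.

On these data alone, whether an amine, a carboxylic acid or a longer chain at this position would give a step beyond the scatter remains open. Also open, as far as these compounds go, is whether changes to the (3-methylbut-2-en-1-yl)oxy group or the (1,3-thiazol-2-yl)amino group would do so.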